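The source may hold more compounds than are shown below. What is called first, only, known or untested is meant among the compounds shown, and "the series" means these compounds.

Measured in a functional assay on A549 cells (Homo sapiens) for antiproliferative activity, read by MTT assay, with a stated time of 72 h; on this read-out higher numbers stand for weaker inhibition and lower numbers for stronger inhibition:
Compound 1 `CC/C=C/C(=O)Nc1cccc(Oc2nc(Nc3ccn(C)n3)nc3c2CSCC3)c1`: 36800 nM
Compound 2 `CCC/C=C/C(=O)Nc1cccc(Oc2nc(Nc3ccn(C)n3)nc3c2CSCC3)c1`: 8190 nM
Compound 3 `C=C(C)C(=O)Nc1cccc(Oc2nc(Nc3ccn(C)n3)nc3c2CSCC3)c1`: 46900 nM
Compound 4 `CC/C=C/C(=O)Nc1cccc(Oc2nc(Nc3cccc(OC)c3)nc3c2CSCC3)c1`: not yet measured

Two numbers sit together at the high end, with a 1.3-fold higher number from compound 1 to compound 3 (0.11 log units; within the scatter), and the third lies apart, with a 4.5-fold lower number from compound 1 to compound 2 (0.65 log units; beyond the scatter). The next structure changes another part of the molecule: 3-methoxyphenyl in place of 1-methyl-1H-pyrazol-3-yl on a nitrogen on an aromatic ring. Among the compounds with values here, no measured step touches that place. All of them alter the group on the carbonyl carbon, so even the largest, a 5.7-fold higher number from compound 2 to compound 3 (0.76 log units; beyond the scatter), is only a rough guide to size. In this assay a modest step is therefore expected, tentatively downward, as compound 1 at 36800 nM already lies at the high end. The expected step is a 1.8-fold lower number from compound 1 to compound 4 (0.26 log units; within the scatter). The estimate for compound 4 is 20000 nM, with an expected range from 6000 nM to 60000 nM.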

Compound 4, half-maximal inhibitory concentration: 17200 nM
Compound 4: middle estimate off by 1.2-fold (0.07 log units), on the high side; measured number inside the range.
By their numbers in this assay, from the lowest: compound 2; then compound 4; then compounds 1 and 3 (each within the scatter of the next).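

In this assay, the group on the nitrogen on an aromatic ring emerges as a second place that moves the number: with the carbonyl side held constant, 3-methoxyphenyl in place of 1-methyl-1H-pyrazol-3-yl gives a 2.1-fold lower number from compound 1 to compound 4 (0.33 log units; beyond the scatter) as a modest step beyond the scatter. The five-membered ring with two hetero atoms is thus not required for this level of activity, since a six-membered ring of carbon only serves there. No available evidence bears on the reason for this step. As far as these compounds go, it remains open whether the step carries over to the pent-1-en-1-yl group of compound 2, and how an unsubstituted phenyl or a pyridine ring would read on that nitrogen.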